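Adding a Methyl to the Chain of Compound 3

A few compounds are considered here, and "the series" means these few. Any claim that something is new, unique, unknown or untested is made for them only; others in the source may bear on it.

Measured so far:
compound 1, `CC(C)(C)[C@H](C(=O)Nc1ncc(F)s1)c1ccc(Cl)cc1`: 92%
compound 2, `C[C@H](C(=O)Nc1nccs1)c1ccc(Cl)cc1`: 83%
compound 3, `CCC[C@H](C(=O)Nc1nccs1)c1ccc(Cl)cc1`: 108%

Of the compounds shown here, three sharing one core have been tested in a functional assay on CHO cells for agonist activity at Free fatty acid receptor 2 (Homo sapiens), read by cAMP accumulation; a higher number here means a larger maximal response, a lower number a smaller maximal response. Compound 3 gives 108%, the highest of the three numbers. Compound 1 gives 92%, and compound 2 gives 83%; both gaps to compound 3 lie beyond the scatter. Going by the values given here, only one measured step speaks to the length of the saturated chain: a number 25 percentage points higher from compound 2 to compound 3 (beyond the scatter), a modest gain when the chain grows.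

Compound 4, `CC(C)C[C@H](C(=O)Nc1nccs1)c1ccc(Cl)cc1`, is the next step. It differs from compound 3 by methyl in place of hydrogen on a saturated chain carbon bound to two saturated chain carbons. Read one bond further out, this turns propyl into isobutyl. Among the compounds with values here, the step from compound 2 to compound 3 suggests that a longer chain does not hurt and may help, but compound 3 already stands above the control, and no measured pair tests a methyl at this place. The step of no change at the digits printed from compound 3 to compound 4 (within the scatter) is therefore expected to be small, within or just beyond the scatter, with a slight lean upward. For compound 4 the expected value in this assay is 108%, with a likely range from 88% to 126%.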

Compound 4, largest response reached (reported as efficacy), in percent of the reference or control that the assay uses: 68%
Compound 4: middle estimate off by 40 percentage points, on the high side, and the stated range ends above it.
By their numbers in this assay, from the lowest: compound 4; then compounds 2 and 1 (each within the scatter of the next); then compound 3.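

In this assay, one added methyl on a saturated chain carbon bound to two saturated chain carbons changes the outcome sharply: the response falls, with a number 40 percentage points lower from compound 3 to compound 4 (beyond the scatter). Lengthening the chain therefore does not raise the number on its own, since the isobutyl compound also ends up under the compound with the shorter methyl group, with a number 15 percentage points lower from compound 2 to compound 4 (beyond the scatter). Nothing available here explains this drop.

The compounds shown cannot separate the effect of the branch from the effect of the extra carbon, and a straight butyl chain would be the direct test of that. From the compounds shown here alone, how a hydroxyl group or an amine on this same chain carbon would change the response also remains open.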